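Removing the chain methyl of compound 3

The compounds below may be only part of what the source reports. "The series", "measured", "known", "first", "only" and "open" are said of these compounds alone.

Three compounds of the series have numbers in a functional assay (lung) for inhibition, with Cavia porcellus as the target; on this read-out higher numbers stand for weaker inhibition and lower numbers for stronger inhibition. Compound 1 `CCCC(CCc1nnn[nH]1)Cc1cccc(OCc2ccc3ccccc3n2)c1` gives 16 nM; compound 2 `c1ccc2nc(COc3ccc(OCCCc4nnn[nH]4)cc3)ccc2c1` gives 250 nM; compound 3 `CC(CCCC(=O)O)c1cccc(OCc2ccc3ccccc3n2)c1` gives 500 nM. Compound 3 stands highest of the three: its gap to compound 2 is within the scatter, its gap to compound 1 is beyond it. Compound 4 `O=C(O)CCCCc1cccc(OCc2ccc3ccccc3n2)c1` differs from compound 3 by one change: hydrogen in place of methyl on a saturated chain carbon bound to an aromatic carbon and a saturated chain carbon. Among the compounds with values here, no pair of measured compounds shows this change, so its size is unknown from these data. The step is expected to be small, in no set direction, with no change at the digits printed from compound 3 to compound 4 (within the scatter) expected to stay within the scatter. Compound 4 is estimated at 500 nM, with a range from 170 nM to 1500 nM.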

Compound 4, half-maximal inhibitory concentration: 370 nM
Estimate against measurement, compound 4: 1.4-fold (0.13 log units) above; low and high end bracket the measured number.
By their numbers in this assay, from the lowest: compound 1; then compounds 2, 4 and 3 (each within the scatter of the next).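

In this assay this position now has its first measured change, and the step is a 1.4-fold lower number from compound 3 to compound 4 (0.13 log units; within the scatter). The methyl on this saturated chain carbon can therefore be replaced by hydrogen with the carboxylic acid compounds staying within the scatter of each other. No measurement on hand gives a reason for this step.

From the compounds shown here alone, whether a larger group here, such as ethyl, isopropyl or phenyl, would behave the same remains open. So does the outcome for a hydroxyl or fluorine on this carbon.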